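Serine side chain on a coumarin-like amide: expected binding

A few compounds are considered here, and "the series" means these few. Any claim that something is new, unique, unknown or untested is made for them only; others in the source may bear on it.

Measured so far in an assay on HEK293 cells for displacement of a labelled ligand from adenosine receptor A2b (Homo sapiens), read by scintillation counting, with a stated time of 30 min, tested at 10 uM; a lower number here means less inhibition, a higher number more inhibition at the concentration tested (going by the name of the read-out):
Compound 1 `COc1cccc2cc(C(=O)NCC(=O)O)c(=O)oc12` gives 35%.
Compound 2 `COCCNC(=O)c1cc2cccc(OC)c2oc1=O` gives 18%.
Compound 3 `COc1cccc2cc(C(=O)Nc3c(C#N)ncn3-c3ccc(C#N)cc3)c(=N)oc12` gives 10%.

Compound 2 sits between the other two on these numbers: its gap to compound 3 lies within the scatter of this kind of measurement, while its gap to compound 1 lies beyond it. The unmeasured compound 4 `COc1cccc2cc(C(=O)N[C@@H](CO)C(=O)O)c(=O)oc12` differs from compound 2 in one place: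

1-carboxy-2-hydroxyethyl in place of 2-methoxyethyl on an amide-type nitrogen

One measured step speaks to this change. Going a number 17 percentage points lower from compound 1 to compound 2 (beyond the scatter), the carboxy on the chain carbon was replaced by methoxymethyl and the read-out dropped. Compound 4 brings the carboxy back, now joined by a hydroxymethyl on the same carbon, so the move from compound 2 is roughly that step run backwards. An increase back toward the number of compound 1 is therefore expected, as a number 12 percentage points higher from compound 2 to compound 4 (beyond the scatter). In this assay compound 4 is estimated to give about 30%, with a likely range from 15% to 45%.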

Compound 4, a percentage reported as inhibition, at one concentration (the size of the read-out at that concentration, not a potency): 24%
Compound 4: middle estimate off by 6 percentage points, on the high side, within the range that was stated.
By their numbers in this assay, from the lowest: compounds 3, 2 and 4 (each within the scatter of the next, the first and the last beyond it); then compound 1.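

In this assay, the step for placing hydroxymethyl in place of hydrogen on the saturated chain carbon is a number 11 percentage points lower from compound 1 to compound 4 (beyond the scatter) so this carbon does not take the added group without a change in the read-out. The exchange of the 2-methoxyethyl for the 1-carboxy-2-hydroxyethyl is a number 6 percentage points higher from compound 2 to compound 4 (within the scatter) so bringing back the carboxy together with the hydroxymethyl does not set these two side chains apart on this read-out. No measured evidence accompanies these numbers to explain either step.

The compounds shown leave open whether another group on that same chain carbon, such as a methyl or an amine, would behave as hydroxymethyl does. They also leave open what a longer chain carrying the carboxylic acid on the amide-type nitrogen would give.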